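The source may hold more compounds than are shown below. What is called first, only, known or untested is meant among the compounds shown, and "the series" means these compounds.

Working notes on the series. In a functional assay on MCF7 cells (Homo sapiens) for antiproliferative activity, read by MTT assay, with a stated time of 72 h (a higher number here means a weaker inhibitor, a lower number a stronger inhibitor), compound 1 `O=C(N/N=C/c1ccccc1)Nc1ccc(Oc2ccnc3[nH]ccc23)c(F)c1` gives 2380 nM. Compound 2 `O=C(N/N=C/c1cccc(Cl)c1Cl)Nc1ccc(Oc2ccnc3[nH]ccc23)c(F)c1` gives "not active" (no number reported), so it stands without a single number and offers no value to measure from. Compound 3 `COc1ccc(/C=N/NC(=O)Nc2ccc(Oc3ccnc4[nH]ccc34)c(F)c2)cc1` has not yet been measured. The structural change is 4-methoxyphenyl in place of 2,3-dichlorophenyl on a carbon with a double bond to nitrogen, with 4-methoxyphenyl in place of 2,3-dichlorophenyl on a carbon with a double bond to nitrogen. Among the compounds with values here, no measured step sizes this change, and the missing number for compound 2 leaves any step from it undefined. In this assay, the expected direction is towards stronger inhibition, from no reported number to a measurable one, though the size of that move cannot be stated. Within the data shown here, the only numerical anchor is compound 1 at 2380 nM, and a result of no reported number remains possible. Compound 3 is estimated at 3000 nM, with an expected range of 800 nM to 12000 nM.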

Compound 3, half-maximal inhibitory concentration: 5750 nM
For compound 3 the middle estimate is 1.9-fold (0.28 log units) below the measured one, and the stated range covers the measured number.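

In this assay, methoxy in place of hydrogen on an aromatic carbon gives a 2.4-fold higher number from compound 1 to compound 3 (0.38 log units; beyond the scatter), so the 4-methoxyphenyl group on this carbon with a double bond to nitrogen keeps a measurable number, but a modestly weaker one than the unsubstituted phenyl group of compound 1. Within the data shown here, compound 2 has no number, so no step from it to any other compound can be read, and the comparison of 2,3-dichlorophenyl with 4-methoxyphenyl goes no further than a measured number for compound 3 against none for compound 2. No measured evidence on hand accounts for the step.

The compounds shown leave open whether this step belongs to methoxy specifically or would also appear with a hydroxyl, an ethoxy or a dimethylamino group in its place. They also leave open whether a single chlorine on the phenyl ring would give a number.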